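The source may hold more compounds than are shown below. What is called first, only, known or untested is meant among the compounds shown, and "the series" means these compounds.

Compound 1 `CC(C)[S+]([O-])CCCCN=C=S` gives 2050 nM
Compound 2 `[O-][S+](CCCCN=C=S)Cc1ccccc1` gives 2850 nM

Both numbers come from a functional assay on HepG2 cells (Homo sapiens) for cytotoxicity, read by MTT assay, with a stated time of 72 h (on this read-out lower numbers stand for stronger inhibition and higher numbers for weaker inhibition), and are all that has been measured so far. Compound 2 stands level with compound 1: their two values lie within the usual scatter of repeated measurements, so neither can be ranked above the other.

The next compound, compound 3 `COc1ccc(C[S+]([O-])CCCCN=C=S)cc1`, differs from compound 2 in one place. It carries methoxy in place of hydrogen on an aromatic carbon, para to a large group (methoxy in place of hydrogen on an aromatic carbon). Among the compounds with values here, no measured pair yet shows what this change does in this assay and the evidence is thin. Within the data shown here, the only guide is that compound 1 at 2050 nM and compound 2 at 2850 nM sit within the scatter of each other. A step beyond the scatter, in either direction, is therefore not expected. The expected change (a 1.1-fold lower number from compound 2 to compound 3 (0.06 log units; within the scatter)) is small and stays within the scatter. For compound 3 the estimated value is 2500 nM with an expected range from 1100 nM to 5500 nM in this same test.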

Compound 3, half-maximal inhibitory concentration: 4620 nM
Compound 3: middle estimate off by 1.8-fold (0.27 log units), on the low side; measured number inside the range.
By their numbers in this assay, from the lowest: compounds 1, 2 and 3 (each within the scatter of the next, the first and the last beyond it).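

Within the data shown here, this is the first measured pair for this change: in this assay, methoxy in place of hydrogen on an aromatic carbon, para to a large group, gives a 1.6-fold higher number from compound 2 to compound 3 (0.21 log units; within the scatter) and so stays within what repeated measurements of a single compound can show. Compound 2 and compound 3 therefore cannot be ranked, and adding these 2 heavy atoms, with their 1 hydrogen-bond acceptor, has no effect here that can be told from the scatter. This one pair shows only what methoxy does at this place on the ring of compound 2, and it sets no rule for other groups or other places.

The compounds shown leave open what a different group at this same place would give, for instance an amine, a carboxylic acid or a longer chain, and whether any of these would move the number beyond the scatter. They also leave open whether methoxy elsewhere on the ring would give a similar number. Nothing available offers an explanation for this result.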